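The compounds below may be only part of what the source reports. "The series", "measured", "known", "first", "only" and "open" are said of these compounds alone.

Measured so far:
compound 1 `O=c1[nH]nc2n(c1=O)CCN2c1ccccc1`: 7%
compound 2 `Cc1ccccc1N1CCn2c1n[nH]c(=O)c2=O`: 0%
compound 3 `COc1ccccc1N1CCn2c1n[nH]c(=O)c2=O`: 26%

All three share one core and differ only in what sits on the phenyl ring. In an ADME assay on Vero cells (Chlorocebus sabaeus) for cytotoxicity, with a stated time of 72 h, tested at 10 ug/mL (on this read-out higher numbers stand for a stronger effect at the one concentration tested and lower numbers for a weaker effect), compound 1 stands second highest of the three numbers. Its nearest neighbour is compound 2, reached by a methyl in place of hydrogen, with a number 7 percentage points lower from compound 1 to compound 2 (within the scatter). Its furthest neighbour is compound 3, reached by a methoxy in place of hydrogen, with a number 19 percentage points higher from compound 1 to compound 3 (beyond the scatter). Between the two substituted compounds, a number 26 percentage points higher from compound 2 to compound 3 (beyond the scatter).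

Compound 4 `O=c1[nH]nc2n(c1=O)CCN2c1ccc(Cl)cc1` has not yet been measured. It differs from compound 1 in one place: chloro in place of hydrogen on an aromatic carbon. Among the compounds with values here, no measured step introduces a chloro, so the two steps starting from compound 1 are the only guide: the methyl step stayed within the scatter, and the methoxy step gave a modest rise. A single small group on that ring has therefore moved the read-out only a little, in either direction. The step from compound 1 to compound 4 is accordingly expected to be small, most likely not beyond the scatter, with a number 5 percentage points higher from compound 1 to compound 4 (within the scatter). Compound 4 is estimated at 12%, within a range of 0% to 30%.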

Compound 4, a percentage reported as inhibition, at one concentration (the size of the read-out at that concentration, not a potency): 0%
For compound 4 the middle estimate is 12 percentage points above the measured one; low and high end bracket the measured number.
By their numbers in this assay, from the lowest: compounds 2, 4 and 1 (each within the scatter of the next); then compound 3.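

A chloro in place of hydrogen, on an aromatic carbon para to a large group, adds one heavy atom to the ring, and in this assay it gives a number 7 percentage points lower from compound 1 to compound 4 (within the scatter) and so brings no measurable change. Within the data shown here, this is the first halogen in the set, and it shows that the ring of compound 1 can carry a chloro at this place without a step beyond the scatter. Like the methyl of compound 2, the chloro stays within the scatter of compound 1, while the methoxy of compound 3 goes against that picture, and no measurement at hand bears on the reason for any of these results.

Still open, going by these compounds, is whether the rise seen with the methoxy of compound 3 belongs to the group itself or to where it sits on the ring, which a methoxy para to a large group would help to settle. On these data alone, it is equally open how a group of another kind at this place, such as an amine or a carboxylic acid, would behave, and a single tested concentration says nothing about potency.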